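The compounds below may be only part of what the source reports. "The series", "measured", "known", "first", "only" and "open" are said of these compounds alone.

In an ADME assay on BHK-21 cells (Mesocricetus auratus) for cytotoxicity, read by MTT assay, with a stated time of 72 h (on this read-out lower numbers stand for higher toxicity in this test and higher numbers for lower toxicity in this test), compound 1 `NS(=O)(=O)c1ccc(N2N=C(c3ccc(OCc4ccccc4)cc3)CC2c2ccccc2)cc1` gives 80000 nM and compound 2 `NS(=O)(=O)c1ccc(N2N=C(c3ccc(OCc4ccccc4)cc3)CC2c2ccccc2F)cc1` gives 90000 nM. These two numbers lie within the usual scatter of each other, so compound 2 stands level with compound 1. The next compound, compound 3 `NS(=O)(=O)c1ccc(N2N=C(c3ccc(OCc4ccccc4)cc3)CC2c2cccc(Cl)c2)cc1`, carries 3-chlorophenyl in place of 2-fluorophenyl on a saturated ring carbon. Among the measured compounds shown here, only one measured step bears on this swap: fluoro in place of hydrogen on an aromatic carbon, which gave a 1.1-fold higher number from compound 1 to compound 2 (0.05 log units; within the scatter), within the scatter. For the measured compounds named here, no compound with chlorine has been measured yet, so this guide is thin. Going by a 1.1-fold higher number from compound 1 to compound 2 (0.05 log units; within the scatter), no step beyond the scatter is expected in this assay, in either direction. The estimated step is a 1.1-fold lower number from compound 2 to compound 3 (0.05 log units; within the scatter). For compound 3 the expected value is 80000 nM, with an estimated range from 40000 nM to 160000 nM.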

Compound 3, half-maximal cytotoxic concentration: 45000 nM
Compound 3: the middle estimate sits 1.8-fold (0.25 log units) above what was measured; measured number inside the range.
By their numbers in this assay, from the lowest: compounds 3, 1 and 2 (each within the scatter of the next).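

In this assay, the phenyl ring on the saturated ring carbon now carries chlorine as well as fluorine: 3-chlorophenyl in place of 2-fluorophenyl gives a 2.0-fold lower number from compound 2 to compound 3 (0.30 log units; within the scatter), and chloro in place of hydrogen gives a 1.8-fold lower number from compound 1 to compound 3 (0.25 log units; within the scatter). Both steps lie within the scatter, so a change of halogen and of its place on this ring, like the earlier fluoro step, leaves compounds 1, 2 and 3 level in this test. Nothing available here explains these numbers.

Open, on these data alone, is whether 2-chlorophenyl would read the same as 3-chlorophenyl, since compound 3 differs from compound 2 in both the halogen and its place on the ring. Also open, as far as these compounds go, is whether a group of another kind on this phenyl ring, such as an amine or a carboxylic acid, would stay level too.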